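This account rests on a few compounds, and the source may have more. Where it says the series, first, only, none or still open, it means among the compounds named here.

In a functional assay on HepG2 cells (Homo sapiens) for inhibition, read by MTT assay, with a stated time of 72 h (a lower number here means a stronger inhibitor, a higher number a weaker inhibitor), compound 1, `Cc1nc(N(C)C(=O)NC(=O)c2c(F)cccc2F)sc1C(=O)N/N=C/c1ccc(Cl)cc1Cl`, gives 70 ug/mL.
In this assay compound 2, `Cc1nc(N(C)C(=O)NC(=O)c2c(F)cccc2F)sc1C(=O)N/N=C/c1ccccc1C(F)(F)F`, gives 1.11 ug/mL.

Among the measured compounds shown here, compound 2 holds the lower of the two numbers in this assay, and the only measured step, a 63-fold lower number from compound 1 to compound 2 (1.80 log units; beyond the scatter), separates it from compound 1. That step shows how far an exchange of the group on the carbon with a double bond to nitrogen can move the read-out.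

Compound 3, `COc1cc(/C=N/NC(=O)c2sc(N(C)C(=O)NC(=O)c3c(F)cccc3F)nc2C)cc(OC)c1OC`, is not yet measured. It differs from compound 2 in one place: 3,4,5-trimethoxyphenyl in place of 2-(trifluoromethyl)phenyl on a carbon with a double bond to nitrogen. For the measured compounds named here, no measured step covers the trimethoxyphenyl itself, so the step of a 63-fold lower number from compound 1 to compound 2 (1.80 log units; beyond the scatter) speaks only to the size such a swap may reach, not to its direction. Because compound 2 stands lowest at 1.11 ug/mL, a rise is the more likely outcome, and a sizeable one is possible. Compound 3 is therefore expected to give about 8 ug/mL, within 1 ug/mL to 60 ug/mL, corresponding to an expected step of a 7.2-fold higher number from compound 2 to compound 3 (0.86 log units; beyond the scatter).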

Compound 3, half-maximal inhibitory concentration: > 100 ug/mL
Compound 3 was reported as a limit; the forecaster's own chance of this, stated with the estimate: 10%; middle value at least 12-fold (1.09 log units) away from the limit.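

In this assay, 3,4,5-trimethoxyphenyl in place of 2-(trifluoromethyl)phenyl on the carbon with a double bond to nitrogen gives an at least 90-fold higher number from compound 2 to compound 3 (1.95 log units; beyond the scatter), so a second exchange at this place also ends far from the low number, and of the three groups shown only 2-(trifluoromethyl)phenyl gives one. The reading for compound 3 is a limit of the assay and not a number: the limit of > 100 ug/mL in this assay, at which 1 of the 3 values shown sits. Against 2,4-dichlorophenyl, the same entering group gives an at least 1.4-fold higher number from compound 1 to compound 3 (0.15 log units; that floor lies within the scatter), and the two groups cannot be put in order from these readings.

On these data alone, it remains open whether a plain phenyl, a pyridine ring, or a phenyl carrying a single chlorine or a single methoxy group would stay near compound 2 or move away from it. Also open, as far as these compounds go, is how far the true value of compound 3 lies from its limit.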